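The source may hold more compounds than are shown below. What is called first, only, known or untested is meant among the compounds shown, and "the series" means these compounds.

Three compounds share one core and differ only in the group carried on one aromatic carbon. Compound 1 `NC(=O)c1c(NC(=O)c2ccccc2)sc2c1CCN(C(=S)Nc1ccccc1Cl)C2` carries hydrogen there, and in a functional assay on MKN-74 cells (Homo sapiens) for antiproliferative activity, with a stated time of 24 h (a lower number here means a stronger inhibitor, a higher number a weaker inhibitor), compound 1 gives 11800 nM. Compound 2 `NC(=O)c1c(NC(=O)c2ccccc2F)sc2c1CCN(C(=S)Nc1ccccc1Cl)C2` carries fluoro, and in this assay compound 2 gives 11100 nM. Compound 3 `NC(=O)c1c(NC(=O)c2ccccc2Br)sc2c1CCN(C(=S)Nc1ccccc1Cl)C2` carries bromo, and in this assay compound 3 gives 12900 nM. The three numbers lie within the usual scatter of one another: the step of a 1.1-fold higher number from compound 1 to compound 3 (0.04 log units; within the scatter) and the step of a 1.2-fold higher number from compound 2 to compound 3 (0.07 log units; within the scatter) are both too small to count as a change, so compound 3 stands with the other two rather than apart from them.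

Compound 4 `NC(=O)c1c(NC(=O)c2ccccc2I)sc2c1CCN(C(=S)Nc1ccccc1Cl)C2` continues the same series with iodo in place of bromo on an aromatic carbon. Within the data shown here, the steps that bear on this change are the ones that already swapped groups on this carbon: hydrogen to fluoro a 1.1-fold lower number from compound 1 to compound 2 (0.03 log units; within the scatter), hydrogen to bromo a 1.1-fold higher number from compound 1 to compound 3 (0.04 log units; within the scatter) and fluoro to bromo a 1.2-fold higher number from compound 2 to compound 3 (0.07 log units; within the scatter), none of which moved beyond the scatter. Another halogen at the same place is therefore expected to leave this assay unchanged beyond the scatter, the expected step being a 1.0-fold higher number from compound 3 to compound 4 (0.00 log units; within the scatter). Compound 4 is estimated at 13000 nM, with a range from 7000 nM to 25000 nM.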

Compound 4, half-maximal inhibitory concentration: 17500 nM
Compound 4: the middle estimate sits 1.3-fold (0.13 log units) below what was measured, within the range that was stated.
By their numbers in this assay, from the lowest: compounds 2, 1, 3 and 4 (each within the scatter of the next).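

Iodo adds one more atom to the set tried on this aromatic carbon, and in this assay the swap from bromo gives a 1.4-fold higher number from compound 3 to compound 4 (0.13 log units; within the scatter) while the comparison with fluoro gives a 1.6-fold higher number from compound 2 to compound 4 (0.20 log units; within the scatter) and the comparison with hydrogen gives a 1.5-fold higher number from compound 1 to compound 4 (0.17 log units; within the scatter) at this same place. All three steps stay within the scatter, so hydrogen, fluoro, bromo and iodo cannot be told apart here, and the four compounds show no trend along the halogens. Nothing available explains why such different atoms on this carbon leave the number so little changed.

The compounds shown keep to hydrogen and halogens on this one carbon, so it remains open whether an amine, a carboxylic acid, a methoxy group or a longer chain there would move the number beyond the scatter. Also open, from the compounds shown here alone, is whether a halogen on another carbon of this ring, or a change elsewhere on the shared core, would do so, and these four compounds do not show which part of the molecule the activity depends on.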